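Chain Length and Chalcogen in Macrophage Cytotoxicity

The compounds below may be only part of what the source reports. "The series", "measured", "known", "first", "only" and "open" are said of these compounds alone.

Compound 1 `O=S(=O)(O)OCCCCCCCC[Te]c1ccccc1` gives 3950 nM in a functional assay on RAW264.7 cells (Mus musculus) for cytotoxicity, read by MTT assay, with a stated time of 24 h; on this read-out higher numbers stand for weaker inhibition and lower numbers for stronger inhibition.
Compound 2 `O=S(=O)(O)OCCCCCCCC[Se]c1ccccc1` reaches only the limit of this assay, reported as > 100000 nM.
Compound 3 `O=S(=O)(O)OCCCCCCCCCC[Te]c1ccccc1` gives 5320 nM.

Compound 2 thus stands at a limit rather than a number, namely (the limit of > 100000 nM in this assay, at which 1 of the 3 values shown sits). Compound 4 `O=S(=O)(O)OCCCCCCCCC[Se]c1ccccc1` differs from it by one change: (sulfooxy)methyl in place of sulfooxy on a saturated chain carbon, eight bonds along the chain from a selenium atom. Going by the values given here, the only measured step that bears on this is a lengthening of the same chain in the tellurium pair, a 1.3-fold higher number from compound 1 to compound 3 (0.13 log units; within the scatter), which stayed within the scatter. A comparable lengthening in the selenium pair is therefore expected to give no step beyond the scatter, a step that the limit leaves unreadable from compound 2 to compound 4, and compound 4 is expected to sit again at or near the limit. The estimate for compound 4 is 150000 nM, with a range from 50000 nM to 500000 nM.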

Compound 4, half-maximal inhibitory concentration: > 100000 nM
Compound 4 gave a limit, no number; the forecaster's own chance of this, stated with the estimate: 80%; the middle value lies beyond the limit too.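

Compound 2 and compound 4 both give only a limit in this assay, and the step between them cannot be read. The compounds shown leave open whether chain length changes the read-out among the selenium compounds.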